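The compounds below may be only part of what the source reports. "The series", "measured", "known", "first", "only" and "open" are said of these compounds alone.

Compound 1 `COc1ccc(/C=C(/SCc2ccc(F)cc2)C(=O)c2ccc(Br)cc2)cc1O` was tested in a functional assay on DU-145 cells (Homo sapiens) for inhibition, read by trypan blue exclusion, with a stated time of 96 h (a lower number here means a stronger inhibitor of growth, a higher number a weaker inhibitor of growth), where compound 1 gives 1000 nM. Two companions share its core and differ only in the group on a double-bonded chain carbon bound to a double-bonded chain carbon. Compound 2 `O=C(/C(=C\c1c[nH]c2ccc(Cl)cc12)SCc1ccc(F)cc1)c1ccc(Br)cc1` gives 1000 nM, and compound 3 `Cc1ccc(C)c(/C=C(/SCc2ccc(F)cc2)C(=O)c2ccc(Br)cc2)c1` gives 1000 nM. The step of no change at the digits printed from compound 1 to compound 2 (within the scatter) and the step of no change at the digits printed from compound 1 to compound 3 (within the scatter) both stay within the scatter, as does no change at the digits printed from compound 2 to compound 3 (within the scatter), so compound 1 sits level with compounds 2 and 3 and none can be called stronger or weaker.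

Compound 4 `COc1ccc(/C=C(/SCc2ccc(F)cc2)C(=O)c2ccc(C(=O)O)cc2)cc1O` is not yet measured. It keeps the core of compound 1 and changes (carboxy in place of bromo on an aromatic carbon), so that the same difference cut one bond further out reads 4-bromophenyl to 4-carboxyphenyl. Within the data shown here, none of the measured steps touches this part of the molecule; each of them changed the other aryl group and left the numbers flat. Among the measured compounds shown here, there is therefore no measured step that bears on this change, and no direction can be read from the data. The expected step of a 2.0-fold higher number from compound 1 to compound 4 (0.30 log units; within the scatter) is given with a wide range for that reason, and is expected to lie mostly within the scatter. Compound 4 is expected to give 2000 nM, between 500 nM and 10000 nM.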

Compound 4, concentration for 50% growth inhibition: 10000 nM
Estimate against measurement, compound 4: 5.0-fold (0.70 log units) below, within the range that was stated.
By their numbers in this assay, from the lowest: compounds 1, 2 and 3 (each within the scatter of the next); then compound 4.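

The earlier compounds shown here changed only the other aryl group, so they said nothing about the 4-bromophenyl end of the molecule. In this assay, among these compounds, the change from bromo to carboxy on this aromatic carbon gives a 10-fold higher number from compound 1 to compound 4 (1.00 log units; beyond the scatter) and is the first step in this set to lie beyond the scatter, which shows that the number does respond to what this position carries. Bromo, with 0 hydrogen-bond donors and 0 hydrogen-bond acceptors, gives way to carboxy, with 1 hydrogen-bond donor and 1 hydrogen-bond acceptor, but no measurement here bears on which difference between the two groups lies behind the step.

With only bromo and carboxy at this position, the compounds shown cannot tell whether the weaker growth inhibition is particular to the carboxylic acid or would also appear with its methyl ester, an amide or an amine in the same place. From the compounds shown here alone, it also remains open whether the same change would give a step of similar size on compound 2 or compound 3, which carry different groups on the other side of the shared core.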